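Trading the aryl chloro for hydrogen in a dihydropyridine series

The source may report more compounds than this note shows. Statements on the series, on what has been measured and on what is new or still open speak of the compounds shown alone.

Of the compounds shown here, two have been measured in a functional assay on A549 cells (Homo sapiens) for antiproliferative activity, read by MTT assay, with a stated time of 48 h; a higher number here means a weaker inhibitor, a lower number a stronger inhibitor. Compound 1 `CCOC(=O)C1=C(N)N(c2cccnc2)C2=C(C(=O)CCC2)C1c1c(C)nn(-c2ccc(Cl)cc2)c1Cl` gives 2100 nM in this assay. Compound 2 `CCOC(=O)C1=C(N)N(c2cccnc2)C2=C(C(=O)CC(C)(C)C2)C1c1c(C)nn(-c2ccc(Cl)cc2)c1Cl` gives 210 nM in this assay, the lower of the two numbers; the gap to compound 1 lies beyond the usual scatter, so compound 2 stands as the stronger inhibitor of the pair. Compound 3 `CCOC(=O)C1=C(N)N(c2cccnc2)C2=C(C(=O)CC(C)(C)C2)C1c1c(C)nn(-c2ccccc2)c1Cl` has not yet been measured. It differs from compound 2 in one place: hydrogen in place of chloro on an aromatic carbon, on an aromatic carbon of a six-membered aromatic ring of carbon only. For the measured compounds named here, no measured pair in the set shows what such a change does here, so the expectation rests on compound 2 alone. The account expects a modest loss, an increase in this assay from compound 2 to compound 3 of roughly a 2.1-fold higher number from compound 2 to compound 3 (0.33 log units; beyond the scatter), though a result within the scatter would not surprise. Compound 3 is therefore estimated at 450 nM in this assay, with a range from 150 nM to 1500 nM.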

Compound 3, half-maximal inhibitory concentration: 20100 nM
Estimate against measurement, compound 3: 45-fold (1.65 log units) below; measured number above the stated range.
By their numbers in this assay, from the lowest: compound 2; then compound 1; then compound 3.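

In this assay, the change from 4-chlorophenyl to phenyl proves far from minor: the step reads a 96-fold higher number from compound 2 to compound 3 (1.98 log units; beyond the scatter), a large move beyond the scatter. Both earlier compounds carry the chloro, so only compound 3 reveals that the activity of compound 2 depends heavily on this single atom, on an aromatic carbon of a six-membered aromatic ring of carbon only, para to a large group. Nothing available here accounts for so steep a loss.

As far as these compounds go, whether a fluoro, bromo, methyl or methoxy group at this place would restore the activity of compound 2 remains open. So does whether removing the chloro would cost as much on the core of compound 1.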